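A few compounds are considered here, and "the series" means these few. Any claim that something is new, unique, unknown or untested is made for them only; others in the source may bear on it.

Measured in a functional assay on HCT-116 cells (Homo sapiens) for antiproliferative activity, read by MTT assay, with a stated time of 72 h; on this read-out higher numbers stand for weaker inhibition and lower numbers for stronger inhibition:
- compound 1 `O=C1O[C@H]([C@@H](O)Cn2cc(-c3ccc(Br)cc3)nn2)C(OCc2ccccc2)=C1OCc1ccccc1`: 9420 nM
- compound 2 `O=C1O[C@H]([C@@H](O)Cn2cc(-c3cc(C(F)(F)F)cc(C(F)(F)F)c3)nn2)C(OCc2ccccc2)=C1OCc1ccccc1`: 57200 nM

In this assay, compound 1 holds the lower of the two numbers at 9420 nM. The nearest neighbour on the scale is compound 2 at 57200 nM, and that gap lies beyond the scatter. Compound 1 is therefore the better of only two reference points, and the series has little data behind it so far.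

The next compound to be tested is compound 3 `O=C1O[C@H]([C@@H](O)Cn2cc(C3CC3)nn2)C(OCc2ccccc2)=C1OCc1ccccc1`. It carries cyclopropyl in place of 4-bromophenyl on an aromatic carbon of the five-membered aromatic ring with 3 nitrogen: cyclopropyl in place of 4-bromophenyl on an aromatic carbon. Among the compounds with values here, neither measured compound carries cyclopropyl, so no measured step speaks directly to this change. Within the data shown here, the expectation rests on compound 1 at 9420 nM sitting at the low end of the numbers so far, which leaves more room for a move upward than downward. A modest move to a higher number in this assay is expected, and the expected step is a 2.3-fold higher number from compound 1 to compound 3 (0.37 log units; beyond the scatter). For compound 3 the estimated value is 22000 nM, with an expected range of 8000 nM to 60000 nM.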

Compound 3, half-maximal inhibitory concentration: 30400 nM
For compound 3 the middle estimate is 1.4-fold (0.14 log units) below the measured one; low and high end bracket the measured number.
By their numbers in this assay, from the lowest: compound 1; then compounds 3 and 2 (each within the scatter of the next).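

Swapping 4-bromophenyl for cyclopropyl on the aromatic carbon of the five-membered aromatic ring with 3 nitrogen gives a 3.2-fold higher number from compound 1 to compound 3 (0.51 log units; beyond the scatter) in this assay, so this position now has a readable step, and a modest one, on removing the six-membered aromatic ring. The change does not abolish the read-out: compound 3 at 30400 nM and compound 2 at 57200 nM lie within the scatter of each other, so a substituted phenyl group at this position does not by itself set a number apart from the cyclopropyl one, and compound 1 alone stands apart from compound 3. Nothing available on the series bears on what lies behind this step.

The compounds shown leave open whether the lower number of compound 1 goes with the phenyl ring or with its bromine, a question that an unsubstituted phenyl group at this carbon would address. Also open, on these data alone, is how this position responds to groups of another kind, such as an amine, a carboxylic acid or a longer alkyl chain, and whether the step from 4-bromophenyl to cyclopropyl holds on any other core.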